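Adding a chloromethylcarbonyl group to a limit-bound urea

The source may report more compounds than this note shows. Statements on the series, on what has been measured and on what is new or still open speak of the compounds shown alone.

Compound 1 `CCCCOC(=O)N1CCCc2cc(S(=O)(=O)N3CC(c4ccccc4)NC3=O)ccc21`: 9570 nM
Compound 2 `NC(=O)N1CCCc2cc(S(=O)(=O)N3CC(c4ccccc4)NC3=O)ccc21`: > 20000 nM (a limit)
Compound 3 `O=C(CCl)NC(=O)N1CCCc2cc(S(=O)(=O)N3CC(c4ccccc4)NC3=O)ccc21`: not yet measured

The series is followed in a functional assay on SK-OV-3 cells (Homo sapiens) for antiproliferative activity, read by MTT assay; on this read-out lower numbers stand for stronger inhibition and higher numbers for weaker inhibition. There, compound 2 gives > 20000 nM. This is a limit of the assay and not a number, so compound 2 has no exact position and can only be read as the weaker of the two measured compounds.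

The next structural change leads to compound 3: (chloromethyl)carbonyl in place of hydrogen on an amide-type nitrogen. The terminal amide hydrogen of compound 2 thus gives way to (chloromethyl)carbonyl.

Among the measured compounds shown here, only one measured step bears on this change, and it is an indirect guide. It is an at least 2.0-fold higher number from compound 1 to compound 2 (0.32 log units; beyond the scatter), which lies beyond the scatter. In that step, the compound with the larger group on the carbonyl carbon, compound 1 at 9570 nM, has the lower number. On that single step, a move to a lower number in this assay is expected, of uncertain size, with a real chance that compound 3 stays at the limit.

The expected change is an at least 4.0-fold lower number from compound 2 to compound 3 (0.60 log units; beyond the scatter). For compound 3 the estimated value is 5000 nM, with an expected range from 1000 nM to 20000 nM.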

Compound 3, half-maximal inhibitory concentration: 6140 nM
For compound 3 the middle estimate is 1.2-fold (0.09 log units) below the measured one, within the range that was stated.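

In this assay, placing (chloromethyl)carbonyl on the amide-type nitrogen brings the series back from the limit to a measured value, with an at least 3.2-fold lower number from compound 2 to compound 3 (0.51 log units; beyond the scatter), so this nitrogen can carry a substituent without the reading staying out of range. The size of that step is only a lower bound, because compound 2 has a limit and not a number: the limit of > 20000 nM in this assay, at which 1 of the 3 values shown sits. Where ((chloromethyl)carbonyl)amino stands in place of butoxy on the carbonyl carbon, the comparison gives a 1.6-fold lower number from compound 1 to compound 3 (0.19 log units; within the scatter), which lies within the scatter, so these two groups cannot be told apart in this assay and the new substituent shows no gain over butoxy.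

Whether the chlorine itself matters stays open, as the compounds shown include neither a plain acetyl group on this nitrogen nor a longer acyl chain that would separate the chloromethyl end from the carbonyl. As far as these compounds go, it is also open how a simple methyl group on the same nitrogen would read, and so whether a carbonyl at this place is needed at all.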